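Tert-butyl thiadiazole variant of compound 3: expected potency

The source may hold more compounds than are shown below. What is called first, only, known or untested is meant among the compounds shown, and "the series" means these compounds.

Compound 1 `Oc1nnc(-c2ccc(N3CCC(Oc4ccccc4C(F)(F)F)CC3)nn2)s1` gives 6.1 nM in an assay on microsomes from liver for inhibition of acyl-CoA desaturase 1 (Rattus norvegicus); a lower number here means a stronger inhibitor, a higher number a weaker inhibitor. Compound 2 `FC(F)(F)c1ccccc1OC1CCN(c2ccc(-n3ccnc3)nn2)CC1` gives 4 nM, and compound 3 `OCc1nnc(-c2ccc(N3CCC(Oc4ccccc4C(F)(F)F)CC3)nn2)o1` gives 2.9 nM; compound 3 holds the lowest number of the three, with a 2.1-fold lower number from compound 1 to compound 3 (0.32 log units; beyond the scatter) beyond the scatter while a 1.4-fold lower number from compound 2 to compound 3 (0.14 log units; within the scatter) and a 1.5-fold lower number from compound 1 to compound 2 (0.18 log units; within the scatter) are not.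

Compound 4 `CC(C)(C)c1nnc(-c2ccc(N3CCC(Oc4ccccc4C(F)(F)F)CC3)nn2)s1` differs from compound 3 by 5-(tert-butyl)-1,3,4-thiadiazol-2-yl in place of 5-(hydroxymethyl)-1,3,4-oxadiazol-2-yl on an aromatic carbon. Among the measured compounds shown here, the three measured steps all concern the same aromatic carbon and stay small; the thiadiazole ring of compound 4 recurs in compound 1, but no measured step covers the tert-butyl. A step of about a 2.1-fold higher number from compound 3 to compound 4 (0.32 log units; beyond the scatter) is therefore expected, not clearly beyond the scatter. Compound 4 is estimated at 6 nM, with a range from 2 nM to 20 nM.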

Compound 4, half-maximal inhibitory concentration: 710 nM
Beside the measured number, compound 4's estimate is 120-fold (2.07 log units) below it; measured number above the stated range.
By their numbers in this assay, from the lowest: compounds 3, 2 and 1 (each within the scatter of the next, the first and the last beyond it); then compound 4.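

In this assay this aromatic carbon does not accept every five-membered ring substituent: the earlier exchanges stayed small, yet 5-(tert-butyl)-1,3,4-thiadiazol-2-yl gives a 240-fold higher number from compound 3 to compound 4 (2.39 log units; beyond the scatter) and a 180-fold higher number from compound 2 to compound 4 (2.25 log units; beyond the scatter). With the thiadiazole ring kept, tert-butyl in place of hydroxy still gives a 120-fold higher number from compound 1 to compound 4 (2.07 log units; beyond the scatter), so the ring alone does not carry the loss. Nothing available explains this loss.

As far as these compounds go, whether the loss follows the tert-butyl itself or the absence of the hydroxy remains open. A methyl or a methoxy on the same thiadiazole would bear on that question.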